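Imidazole replacements on the shared core: compound 4

A few compounds are considered here, and "the series" means these few. Any claim that something is new, unique, unknown or untested is made for them only; others in the source may bear on it.

The series keeps one shared core and varies the group sitting on a saturated chain carbon bound to an aromatic carbon and a saturated chain carbon. In an assay on CHO cells for displacement of a labelled ligand from prostaglandin E2 receptor EP3 subtype (Homo sapiens), read by radioligand binding (a lower number here means a stronger inhibitor, a higher number a weaker inhibitor), compound 1 `CC(C)C(c1ccc(-c2ccc3cccc(F)c3c2)[nH]c1=O)N1CCCCS1(=O)=O` gives 14 nM, compound 2 `CC(C)C(Cc1ncc[nH]1)c1ccc(-c2ccc3cccc(F)c3c2)[nH]c1=O` gives 11 nM, and compound 3 `Cc1nc(C(c2ccc(-c3ccc4cccc(F)c4c3)[nH]c2=O)C(C)C)[nH]c1C` gives 7 nM. Compound 2 thus sits second highest of the three numbers, with compound 1 nearest and compound 3 furthest, both within the scatter. Compound 4 `Cc1c[nH]c(C(c2ccc(-c3ccc4cccc(F)c4c3)[nH]c2=O)C(C)C)n1` is not yet measured in this assay. It differs from compound 2 by 4-methyl-1H-imidazol-2-yl in place of (1H-imidazol-2-yl)methyl on a saturated chain carbon bound to an aromatic carbon and a saturated chain carbon.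

The step bearing most directly on this change is a 1.6-fold lower number from compound 2 to compound 3 (0.20 log units; within the scatter), where 4,5-dimethyl-1H-imidazol-2-yl stands in place of (1H-imidazol-2-yl)methyl. The broader replacements a 1.3-fold lower number from compound 1 to compound 2 (0.10 log units; within the scatter) and a 2.0-fold lower number from compound 1 to compound 3 (0.30 log units; within the scatter) also stayed inside the scatter. Compound 4, carrying 4-methyl-1H-imidazol-2-yl directly on the chain carbon, is therefore expected to behave much like compound 3, and the step of a 1.4-fold lower number from compound 2 to compound 4 (0.14 log units; within the scatter) is expected to remain within the scatter, leaning if anything toward a lower number because of a 1.6-fold lower number from compound 2 to compound 3 (0.20 log units; within the scatter). Compound 4 is estimated at 8 nM, in the range 3 nM to 22 nM.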

Compound 4, inhibition constant: 12 nM
The estimate for compound 4 lay 1.5-fold (0.18 log units) below the measured number; low and high end bracket the measured number.
By their numbers in this assay, from the lowest: compounds 3, 2, 4 and 1 (each within the scatter of the next).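

Notes on the position: in this assay, 4-methyl-1H-imidazol-2-yl in place of (1H-imidazol-2-yl)methyl, the same atoms joined differently, gives a 1.1-fold higher number from compound 2 to compound 4 (0.04 log units; within the scatter) and so stays within the scatter, which means this assay does not separate these two arrangements on the saturated chain carbon. Hydrogen in place of methyl on an aromatic carbon of the imidazole gives a 1.7-fold higher number from compound 3 to compound 4 (0.23 log units; within the scatter) and the exchange of the six-membered non-aromatic ring group for the methylimidazole gives a 1.2-fold lower number from compound 1 to compound 4 (0.07 log units; within the scatter) with both inside the scatter, so the four groups shown at this position cannot be told apart by their numbers, and the single methyl step adds no readable effect to the earlier picture. Nothing measured here accounts for how closely these numbers lie.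

Open, on these data alone, is whether any group at this saturated chain carbon, such as an amine, a carboxylic acid or a longer chain, would give a step beyond the scatter. Also open, as far as these compounds go, is how 1H-imidazol-2-yl carrying no methyl at all would read when set directly on the chain carbon.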